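The compounds below may be only part of what the source reports. "The series", "measured", "known", "first", "only" and "open" are said of these compounds alone.

Measured so far:
compound 1 `CCC#CCOc1cccc2ccc(N)nc12` gives > 2000 nM in an assay on cells with melanin-concentrating hormone receptor 1 (Homo sapiens) as the target, read by radioligand binding (a higher number here means a weaker inhibitor, a lower number a stronger inhibitor), a limit of the assay.
compound 2 `CSCCOc1cccc2ccc(N)nc12` gives > 2000 nM in this assay, likewise a limit.

Compound 2 thus stands at the limit, with no number of its own. Both values shown sit at the limit of > 2000 nM in this assay, at which 2 of the 2 values shown sit, so the step that the two limits leave unreadable from compound 1 to compound 2 cannot be read. Compound 3 `Nc1ccc2cccc(OCC3CCCO3)c2n1` differs from compound 2 by oxolan-2-yl in place of (methylsulfanyl)methyl on a saturated chain carbon bound to an oxygen on an aromatic ring. Among the measured compounds shown here, no measured step bears on this change, so neither direction nor size can be drawn from the data; the expected step is a step that the limit leaves unreadable from compound 2 to compound 3, most probably again ending at the limit. Compound 3 is estimated at 4000 nM, between 1500 nM and 15000 nM.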

Compound 3, half-maximal inhibitory concentration: > 2000 nM
Compound 3 was reported as a limit; the forecaster's own chance of this, stated with the estimate: 80%; the middle value is on the limit's open side.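

Among the compounds shown here, no step among compound 1, compound 2 and compound 3 can be read, as all three rest on one limit: the limit of > 2000 nM in this assay, at which 3 of the 3 values shown sit.

On these data alone, whether any such side chain on the shared core gives a readable value in this assay remains open.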